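The compounds below may be only part of what the source reports. "The series", "measured", "known", "first", "only" and "open" are said of these compounds alone.

Going by the values given here, in a functional assay on HepG2 cells (Homo sapiens) for antiproliferative activity, read by MTT assay, with a stated time of 48 h (on this read-out lower numbers stand for stronger inhibition and higher numbers for weaker inhibition), compound 1 `O=C(CN1CCCC1)Nc1ccc2ncnc(Nc3cccc(C(F)(F)F)c3)c2c1` gives 25200 nM, the only true number among the measured compounds. Compound 2 `O=C(CN1CCCCC1)Nc1ccc2ncnc(Nc3cccc(C(F)(F)F)c3)c2c1` reads > 100000 nM, which is a limit of the assay and not a number. Compound 3 `CN1CCN(CC(=O)Nc2ccc3ncnc(Nc4cccc(C(F)(F)F)c4)c3c2)CC1` reads > 100000 nM, which is also a limit. Compound 4 `O=C(CN1CCCC1)Nc1ccc2ncnc(Nc3ccc(Br)cc3)c2c1` keeps the pyrrolidin-1-yl group of compound 1 and changes the other end of the molecule: 4-bromophenyl in place of 3-(trifluoromethyl)phenyl on a nitrogen on an aromatic ring. The new group, 4-bromophenyl, sits on a nitrogen on an aromatic ring.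

The two readable steps concern a different place, a saturated chain carbon bound to a carbonyl carbon. Piperidin-1-yl in place of pyrrolidin-1-yl gives an at least 3.9-fold higher number from compound 1 to compound 2 (0.59 log units; beyond the scatter), and 4-methylpiperazin-1-yl in place of pyrrolidin-1-yl gives an at least 3.9-fold higher number from compound 1 to compound 3 (0.59 log units; beyond the scatter). Neither step measures the exchange on the aromatic ring, so they give no direct guide to its size or direction. They do show that a single change to compound 1 can move the number beyond the scatter, which argues for a wide range.

In this assay, no step beyond the scatter is therefore expected, and the estimated step is a 1.2-fold higher number from compound 1 to compound 4 (0.08 log units; within the scatter). The estimate for compound 4 is 30000 nM, with an expected range from 9000 nM to 100000 nM.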

Compound 4, half-maximal inhibitory concentration: > 100000 nM
Compound 4 ended at the assay's limit (the forecaster's own chance of this, stated with the estimate: 25%); middle value at least 3.3-fold (0.52 log units) from the limit.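

The exchange of 3-(trifluoromethyl)phenyl for 4-bromophenyl on a nitrogen on an aromatic ring gives an at least 3.9-fold higher number from compound 1 to compound 4 (0.59 log units; beyond the scatter) in this assay, so this place in the molecule also responds to a single change, and not only the saturated chain carbon bound to a carbonyl carbon. Compound 1 remains the only compound with a true number, and each single change to it shown here, at either place, ends at a limit rather than a number. The step therefore gives only a minimum, and its full size cannot be told because the readings stop at that limit: the limit of > 100000 nM in this assay, at which 3 of the 4 values shown sit.

From the compounds shown here alone, it remains open whether the higher number follows from bromine replacing trifluoromethyl or from the different place of the group on the phenyl ring, a question that a 3-bromophenyl or a 4-(trifluoromethyl)phenyl group on the same nitrogen would separate. Steps between compounds that both sit at the limit cannot be read, so the compounds at the limit cannot be ranked against one another.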